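Adding a Nitro Group to Compound 2

The source may report more compounds than this note shows. Statements on the series, on what has been measured and on what is new or still open speak of the compounds shown alone.

In a functional assay on Bel-7402 cells (Homo sapiens) for inhibition, read by MTT assay, with a stated time of 24 h, tested at 100 ug/mL (on this read-out higher numbers stand for more inhibition of growth at the one concentration tested and lower numbers for less inhibition of growth), compound 2 `O=C(CCCCC(S)CCS)Nc1cccc(C(F)(F)F)c1` gives 25.3% and stands within the scatter of compound 1 `O=C(CCCCC1CCSS1)Nc1ccc([N+](=O)[O-])c(C(F)(F)F)c1` at 23.9% with no order between them. Compound 3 `O=C(CCCCC(S)CCS)Nc1ccc([N+](=O)[O-])c(C(F)(F)F)c1` makes one change to compound 2, nitro in place of hydrogen on an aromatic carbon, ortho to a trifluoromethyl group and para to a large group, counted as nitro in place of hydrogen on an aromatic carbon in all. Going by the values given here, no measured pair isolates this change, but compound 1 also carries nitro and gives 23.9% here, so no step beyond the scatter is expected in this assay for this change. The expected step is a number 0.3 percentage points lower from compound 2 to compound 3 (within the scatter) by this estimate. The estimate for compound 3 is 25% with an expected range from 14% to 38% on this read-out.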

Compound 3, percent growth inhibition at one concentration: 91.7%
Beside the measured number, compound 3's estimate is 66.7 percentage points below it; measured number outside the range, above it.
By their numbers in this assay, from the lowest: compounds 1 and 2 (each within the scatter of the next); then compound 3.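

In this assay, nitro on this aromatic carbon, ortho to a trifluoromethyl group and para to a large group, gives a number 66.4 percentage points higher from compound 2 to compound 3 (beyond the scatter) with the chain kept open. With nitro in both compounds, opening the five-membered ring gives a number 67.8 percentage points higher from compound 1 to compound 3 (beyond the scatter), so nitro at this position does not produce the high number on its own. Nothing here accounts for the size of these steps. Going by these compounds, whether a nitrile or an amine on the same aromatic carbon would give a comparable step remains open, and so does the effect of removing nitro from compound 1.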